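The compounds below may be only part of what the source reports. "The series", "measured", "known", "first", "only" and "open" are said of these compounds alone.

Measured so far:
- compound 1 `Cc1noc(C)c1-c1cnc(N)c(Oc2ccc(C(=O)Nc3ccccc3)cc2)n1`: 10500 nM
- compound 2 `Cc1noc(C)c1-c1cnc(N)c(Oc2ccc(C(=O)Nc3cccc(Cl)c3)cc2)n1`: 1340 nM

In a functional assay on HeLa cells (Homo sapiens) for inhibition, read by MTT assay, with a stated time of 72 h (on this read-out higher numbers stand for weaker inhibition and lower numbers for stronger inhibition), compound 2 gives 1340 nM, the lowest of the two numbers shown. Compound 1 gives 10500 nM in this assay, and the step of a 7.8-fold lower number from compound 1 to compound 2 (0.89 log units; beyond the scatter) separates the two. Compound 3 `Cc1noc(C)c1-c1cnc(N)c(Oc2ccc(C(=O)Nc3cccc(Cl)n3)cc2)n1` differs from compound 2 by 6-chloropyridin-2-yl in place of 3-chlorophenyl on an amide-type nitrogen. Among the compounds with values here, the one measured step, chloro in place of hydrogen on an aromatic carbon, does not bear on this exchange of a ring of carbon only for a ring with one hetero atom carrying the same chloro; no measured pair shows such a change, so no direction can be taken from the data. Compound 3 is therefore expected to stay close to compound 2, with the expected step of a 1.5-fold higher number from compound 2 to compound 3 (0.17 log units; within the scatter) lying within the scatter or only slightly beyond it. For compound 3 the estimate in this assay is 2000 nM, with a range from 600 nM to 7000 nM.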

Compound 3, half-maximal inhibitory concentration: 25500 nM
Compound 3: middle estimate off by 13-fold (1.11 log units), on the low side; measured number outside the range, above it.
By their numbers in this assay, from the lowest: compound 2; then compound 1; then compound 3.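

In this assay, the group on the amide-type nitrogen proves sensitive to the ring itself and not only to the chloro it carries: 6-chloropyridin-2-yl in place of 3-chlorophenyl gives a large step (a 19-fold higher number from compound 2 to compound 3 (1.28 log units; beyond the scatter)). The gain that the chloro brought on the phenyl ring does not carry over to the new ring, and 6-chloropyridin-2-yl in place of phenyl still gives a modest step the other way (a 2.4-fold higher number from compound 1 to compound 3 (0.39 log units; beyond the scatter)). Nothing at hand speaks to the reason for this. From the compounds shown here alone, it remains open whether the loss follows the ring nitrogen alone or its pairing with the chloro, which a plain pyridin-2-yl on the same amide-type nitrogen would separate. Also open, going by these compounds, is how a methoxy group or an amine in place of the chloro of compound 2 would read.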